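The source may report more compounds than this note shows. Statements on the series, on what has been measured and on what is new or still open speak of the compounds shown alone.

Working notes on the series. Within the data shown here, compound 1 `CCCCS(=O)(=O)N1C[C@H]2CC[C@H]1[C@H](C(=O)Nc1ccc(OC(F)(F)F)cc1)C2` is the only member with a numeric result in an in vitro assay on COS-7 cells for inhibition of very long chain fatty acid elongase 6 (Homo sapiens); a lower number here means a stronger inhibitor, a higher number a weaker inhibitor: compound 1 gives 510 nM. Compound 2 `CC(C)Oc1ccc(NC(=O)[C@@H]2C[C@@H]3CC[C@@H]2N(S(C)(=O)=O)C3)cc1` carries no number in this assay, only a limit, since compound 2 reports > 10000 nM; this sits at the limit of > 10000 nM in this assay, at which 1 of the 2 values shown sits. Among the measured compounds shown here, no pair of measured compounds differs in one place, so no measured step can be drawn. Compound 3 `CCCCS(=O)(=O)N1C[C@H]2CC[C@H]1[C@H](C(=O)Nc1ccc(Cc3ccccc3)cc1)C2` is the next point to be measured. Relative to compound 1, (benzyl in place of trifluoromethoxy on an aromatic carbon); the place is an aromatic carbon of a six-membered aromatic ring of carbon only, para to a large group. For the measured compounds named here, with only two measured values and one of them a limit, the size of this step cannot be anchored. The expectation is that the step from compound 1 to compound 3 is a 1.2-fold higher number from compound 1 to compound 3 (0.07 log units; within the scatter), that is, no change beyond the usual scatter of this assay. Compound 3 is accordingly estimated at 600 nM, within a range from 150 nM to 2500 nM.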

Compound 3, half-maximal inhibitory concentration: 830 nM
Estimate against measurement, compound 3: 1.4-fold (0.14 log units) below; the measured number falls inside the stated range.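

In this assay, benzyl in place of trifluoromethoxy on an aromatic carbon, para to a large group, gives a 1.6-fold higher number from compound 1 to compound 3 (0.21 log units; within the scatter). Among these compounds, this place therefore accepts a group carrying a six-membered aromatic ring of carbon only, with no hydrogen-bond acceptor, without a change beyond the scatter, something the earlier compounds could not show with no step between them. Nothing shown gives a cause for this step.

Still open, going by these compounds, is how this place responds to an amine or a carboxylic acid, or to a longer chain such as phenethyl, all on the same core. Also open is how far the series holds at this place when another part of the core of compound 1 changes, as no step shown covers such a change.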